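A Phenyl Swap on a Compound at the Limit

A few compounds are considered here, and "the series" means these few. Any claim that something is new, unique, unknown or untested is made for them only; others in the source may bear on it.

Compound 1 `CC#Cc1nc(C(=O)OCC)cs1` offers only a limit as a starting point. In a functional assay on NCI-H522 cells (Homo sapiens) for cytotoxicity, with a stated time of 3 days (a lower number here means a stronger inhibitor, a higher number a weaker inhibitor), compound 1 gives > 40000 nM, which is a limit and not a number. Compound 2 `C=Cc1nc(C(=O)OCC)cs1` carries vinyl in place of prop-1-yn-1-yl and gives > 40000 nM, also a limit. Compound 3 `C=Cc1nc2ccccc2o1` carries vinyl on a different core and gives > 40000 nM, again a limit. The whole set therefore stands at the limit of > 40000 nM in this assay, at which 3 of the 3 values shown sit.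

Compound 4 `CCOC(=O)c1csc(C#Cc2ccccc2)n1` keeps the core of compound 1 but has phenyl in place of methyl on a triple-bonded carbon. The only measured step among these compounds is a step that the two limits leave unreadable from compound 1 to compound 2. Among the measured compounds shown here, it gives no size to carry over, and no measured compound shows what phenyl does here. For the measured compounds named here, with no active compound to guide the estimate, little or no change is expected in this assay, and any readable number would point towards a stronger inhibitor. The estimated change is an at least 1.1-fold lower number from compound 1 to compound 4 (0.05 log units; that floor lies within the scatter). For compound 4, the estimated value is 35000 nM, with an expected range from 10000 nM to 40000 nM, and a report of only a limit is quite likely.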

Compound 4, half-maximal inhibitory concentration: > 40000 nM
Compound 4 was reported as a limit; the forecaster's own chance of this, stated with the estimate: 65%; at least 1.1-fold (0.05 log units) between middle value and limit.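

Compound 4 and compound 1 both report only a limit, so the step between them cannot be read, and the swap of methyl for phenyl has no size. The set now stands at one reading: the limit of > 40000 nM in this assay, at which 4 of the 4 values shown sit.

The compounds shown leave open which change, if any, would give a readable number in this assay.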